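From Cyclopropyl to a Larger Arm on the Shared Core

This account rests on a few compounds, and the source may have more. Where it says the series, first, only, none or still open, it means among the compounds named here.

Of the compounds shown here, three on a shared core have been tested in an ADME assay on HFF cells (Homo sapiens) for cytotoxicity, read by MTT assay, with a stated time of 72 h; a lower number here means a stronger inhibitor, a higher number a weaker inhibitor. Compound 1 `CCCCc1cn(C[C@H](O)[C@H]2OC(=O)C(OCc3ccccc3)=C2OCc2ccccc2)nn1` gives 26300 nM in this assay. Compound 3 `O=C1O[C@H]([C@@H](O)Cn2cc(C3CC3)nn2)C(OCc2ccccc2)=C1OCc1ccccc1` carries cyclopropyl where compound 1 carries butyl. In this assay compound 3 gives 24300 nM, and the step is a 1.1-fold lower number from compound 1 to compound 3 (0.03 log units; within the scatter). Compound 2 `CCCCCc1ccc(-c2cn(C[C@H](O)[C@H]3OC(=O)C(OCc4ccccc4)=C3OCc3ccccc3)nn2)cc1` reaches only a limit in this assay, > 100000 nM. From compound 1 to compound 2 the step is an at least 3.8-fold higher number from compound 1 to compound 2 (0.58 log units; beyond the scatter), and in the other direction the step is an at least 4.1-fold lower number from compound 2 to compound 3 (0.61 log units; beyond the scatter). Among the numbers shown, compound 3 holds the lowest, with compound 1 nearest and within the scatter. The third value is a limit, (the limit of > 100000 nM in this assay, at which 1 of the 3 values shown sits).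

Compound 4 `Cc1ccc(S(=O)(=O)NCc2cn(C[C@H](O)[C@H]3OC(=O)C(OCc4ccccc4)=C3OCc3ccccc3)nn2)cc1` differs from compound 3 in one place: (((4-methylphenyl)sulfonyl)amino)methyl in place of cyclopropyl on an aromatic carbon. The measured steps that bear on it are the changes of the group on that ring carbon. The small swap from butyl to cyclopropyl moved nothing beyond the scatter, whereas the move to 4-pentylphenyl pushed the number up at least modestly. Compound 4 also gains a large group, so the step of a 2.5-fold higher number from compound 3 to compound 4 (0.39 log units; beyond the scatter) is expected to raise the number, with a fair chance that only a limit is returned. Compound 4 is therefore estimated at 60000 nM, with a range from 25000 nM to 150000 nM.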

Compound 4, half-maximal inhibitory concentration: 50 nM
For compound 4 the middle estimate is 1200-fold (3.08 log units) above the measured one; measured number outside the range, below it.
By their numbers in this assay, from the lowest: compound 4; then compounds 3 and 1 (each within the scatter of the next). At a limit, above all of these: compound 2.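

On this aromatic carbon, the earlier changes in this assay had either stayed within the scatter or raised the number, and only (((4-methylphenyl)sulfonyl)amino)methyl brought a drop, with a 490-fold lower number from compound 3 to compound 4 (2.69 log units; beyond the scatter). The comparison with the butyl compound gives a drop of similar size, with a 530-fold lower number from compound 1 to compound 4 (2.72 log units; beyond the scatter), so the result does not depend on which of these two small groups serves as the reference. A large group on this carbon does not by itself lower the number, since compound 2 carries 4-pentylphenyl and stands far above, with an at least 2000-fold lower number from compound 2 to compound 4 (3.30 log units; beyond the scatter), and that step rests on a limit: the limit of > 100000 nM in this assay, at which 1 of the 4 values shown sits.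

The compounds shown leave open which part of the entering group goes with the drop, a question that an amide in place of the sulfonamide or a plain phenyl in place of 4-methylphenyl would address. They also leave open whether the same group would give a similar number with free hydroxyl groups in place of the benzyloxy groups on the shared core.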